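The source may hold more compounds than are shown below. What is called first, only, known or untested is meant among the compounds shown, and "the series" means these compounds.

Measured in a functional assay on CCRF-CEM cells (Homo sapiens), read by MTT assay, with a stated time of 72 h; a lower number here means a stronger inhibitor, a higher number a weaker inhibitor:
Compound 1 `COc1nc(N)nc2c1c(-c1ccoc1)cn2[C@@H]1O[C@H](CO)[C@@H](O)[C@H]1O`: > 20000 nM (a limit)
Compound 2 `COc1nc(N)nc2c1c(-c1ccsc1)cn2[C@@H]1O[C@H](CO)[C@@H](O)[C@H]1O`: > 20000 nM (a limit)

Neither value is a number. Going by these compounds, compound 2 stands at the limit of > 20000 nM in this assay, at which 2 of the 2 values shown sit, so how far it lies from any real potency is unknown. The next structure, compound 3 `COc1nc(N)nc2c1c(-c1cc3ccccc3o1)cn2[C@@H]1O[C@H](CO)[C@@H](O)[C@H]1O`, carries 1-benzofuran-2-yl in place of thiophen-3-yl on an aromatic carbon. Among the compounds with values here, only one measured step bears on this change, a step that the two limits leave unreadable from compound 1 to compound 2, an exchange of furan-3-yl for thiophen-3-yl, and it gives no size to carry over. With no readable step to build on, no clear movement is expected in this assay, and another reading at the limit is the likeliest result. The expected step is a number no higher from compound 2 to compound 3 (the limit leaves the size open). For compound 3 the estimate is 20000 nM, with an expected range from 8000 nM to 40000 nM.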

Compound 3, half-maximal inhibitory concentration: 12700 nM
Compound 3: middle estimate off by 1.6-fold (0.20 log units), on the high side; the measured number falls inside the stated range.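

Within the data shown here, at this aromatic carbon, 1-benzofuran-2-yl is the only one of the three groups to give a number rather than a limit: in this assay, compound 3 gives 12700 nM. Replacing thiophen-3-yl yields an at least 1.5-fold lower number from compound 2 to compound 3 (0.19 log units; that floor lies within the scatter), and replacing furan-3-yl yields an at least 1.5-fold lower number from compound 1 to compound 3 (0.19 log units; that floor lies within the scatter); both sizes are floors, so the real steps may be larger. Compound 1 and compound 2 both remain limits rather than numbers, so the exchange between them still cannot be read: the limit of > 20000 nM in this assay, at which 2 of the 3 values shown sit.

The compounds shown leave open whether the number depends on the six-membered aromatic ring of carbon only that 1-benzofuran-2-yl brings or on the whole fused group. Going by these compounds, how a plain phenyl ring, or an amine on the same aromatic carbon, would read in this assay also remains open.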